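A few compounds are considered here, and "the series" means these few. Any claim that something is new, unique, unknown or untested is made for them only; others in the source may bear on it.

compound 1 `N#Cc1ccc(Oc2cnccc2SCC(=O)O)c2ccccc12`: 6970 nM
compound 2 `N#Cc1ccc(Oc2cnccc2SCCCC(=O)O)c2ccccc12`: 1230 nM

In an assay on HEK293 cells for inhibition of solute carrier family 22 member 12 (Homo sapiens), read by scintillation counting, with stated times of 30 min and 15 min (a higher number here means a weaker inhibitor, a lower number a stronger inhibitor), compound 2 gives the lowest of the two numbers shown, and its only neighbour is compound 1; the step of a 5.7-fold lower number from compound 1 to compound 2 (0.75 log units; beyond the scatter) lies beyond the scatter. Compound 3 `N#Cc1ccc(Oc2cnccc2SCCCCCC(=O)O)c2ccccc12` differs from compound 2 by 2-carboxyethyl in place of carboxy on a saturated chain carbon, three bonds along the chain from a sulfur, so the chain grows again by the same kind of extension that separates compound 1 from compound 2. Among the measured compounds shown here, that one measured step is the only guide here, and it was modest. A further move toward a lower number is therefore expected, probably smaller than the first, as a 2.1-fold lower number from compound 2 to compound 3 (0.31 log units; beyond the scatter). Compound 3 is estimated at 600 nM, with a likely range from 200 nM to 2500 nM.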

Compound 3, half-maximal inhibitory concentration: 4740 nM
Compound 3: the middle estimate sits 7.9-fold (0.90 log units) below what was measured, outside the stated range (above it).
By their numbers in this assay, from the lowest: compound 2; then compounds 3 and 1 (each within the scatter of the next).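

In this assay, lengthening the chain on the sulfur a second time reverses the earlier improvement, with a 3.9-fold higher number from compound 2 to compound 3 (0.59 log units; beyond the scatter), so the same change does not act the same way twice. The shortest and longest chains give similar numbers, with a 1.5-fold lower number from compound 1 to compound 3 (0.17 log units; within the scatter), which leaves the 3-carboxypropyl chain of compound 2 with the lowest number of the three. Nothing available here explains this turn.

Open, going by these compounds, is where the 2-carboxyethyl and 4-carboxybutyl chains on the sulfur would fall. Also open, on these data alone, is whether an amide in place of the carboxylic acid would show the same dependence on chain length.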